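A few compounds are considered here, and "the series" means these few. Any claim that something is new, unique, unknown or untested is made for them only; others in the source may bear on it.

Compound 1 `Cc1ccc(C2C(C#N)=C(N)N(c3ccc(S(N)(=O)=O)cc3)C3=C2CCCC3)cc1` and compound 2 `N#CC1=C(N)N(c2ccc(S(N)(=O)=O)cc2)C2=C(CCCC2)C1c1ccccc1O` share one core, and they are read in a functional assay on Ehrlich cells (Mus musculus) for cytotoxicity, read by trypan blue exclusion, with a stated time of 2 h, tested at 25 ug/mL; on this read-out lower numbers stand for a weaker effect and higher numbers for a stronger effect at the one concentration tested. In this assay compound 1 gives 30%. In this assay compound 2 gives 40%. The step of a number 10 percentage points higher from compound 1 to compound 2 (within the scatter) lies within the usual scatter of repeated measurements, so on the numbers shown compound 2 cannot be told apart from compound 1, and neither can be called the stronger of the two.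

Compound 3 `N#CC1=C(N)N(c2ccc(S(N)(=O)=O)cc2)C2=C(CCCC2)C1c1ccc([N+](=O)[O-])cc1` has not yet been measured in this assay. It differs from compound 2 in one place: 4-nitrophenyl in place of 2-hydroxyphenyl on a saturated ring carbon. Within the data shown here, the only measured step that speaks to this change is the one from compound 1 to compound 2, which also swaps the group on that same saturated ring carbon, and that step, a number 10 percentage points higher from compound 1 to compound 2 (within the scatter), stayed within the scatter. On this footing no step beyond the scatter is expected in this assay for the change to compound 3 either, in neither direction.

For compound 3 the expected value in this assay is 35%, with a likely range from 20% to 55%, which means an expected step of a number 5 percentage points lower from compound 2 to compound 3 (within the scatter).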

Compound 3, a percentage reported as activity, at one concentration (the size of the read-out at that concentration, not a potency): 5%
Compound 3: middle estimate off by 30 percentage points, on the high side, outside the stated range (below it).
By their numbers in this assay, from the lowest: compound 3; then compounds 1 and 2 (each within the scatter of the next).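

Swapping 2-hydroxyphenyl for 4-nitrophenyl on the saturated ring carbon gives a number 35 percentage points lower from compound 2 to compound 3 (beyond the scatter) in this assay and so shows that this position can change the cytotoxic read-out, which the earlier pair, with its step inside the scatter, could not show. The comparison with the 4-methylphenyl compound points the same way, with nitro in place of methyl on an aromatic carbon giving a number 25 percentage points lower from compound 1 to compound 3 (beyond the scatter) so compound 3 is the weakest of the three, and a change on the phenyl ring alone is enough to lower the number. Nothing measured here accounts for this fall in activity.

The compounds shown do not separate the nitro group from its place on the phenyl ring, since compound 2 carries its hydroxyl at a different ring position; 2-nitrophenyl and 4-hydroxyphenyl groups would pull these two apart. A 4-aminophenyl or 4-carboxyphenyl group at the same carbon would show whether the low number belongs to nitro alone or extends to other groups at that spot.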